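From Methylamino to Dimethylamino Against a Cytotoxicity Limit

A few compounds are considered here, and "the series" means these few. Any claim that something is new, unique, unknown or untested is made for them only; others in the source may bear on it.

In an ADME assay on CCRF-CEM cells (Homo sapiens) for cytotoxicity, with a stated time of 5 days (a lower number here means a stronger inhibitor, a higher number a weaker inhibitor), compound 1 (`[N-]=[N+]=N[C@H]1C[C@H](n2cnc3c(NC4CC4)nc(Cl)nc32)O[C@@H]1CO`) gives > 100000 nM as a limit of the assay and not as a number. Compound 2 (`CNc1nc(Cl)nc2c1ncn2[C@H]1C[C@H](N=[N+]=[N-])[C@@H](CO)O1`) gives > 100000 nM in this assay and this too is only a limit. The picture so far is the limit of > 100000 nM in this assay, at which 2 of the 2 values shown sit, with no number among them. Going by the values given here, the only measured step is a step that the two limits leave unreadable from compound 1 to compound 2 for methyl in place of cyclopropyl on a nitrogen on an aromatic ring. Compound 3 (`CN(C)c1nc(Cl)nc2c1ncn2[C@H]1C[C@H](N=[N+]=[N-])[C@@H](CO)O1`) differs from compound 2 by methyl in place of hydrogen on a nitrogen on an aromatic ring in one place, methylamino to dimethylamino, with methyl in place of hydrogen on a nitrogen on an aromatic ring. With only a step that the two limits leave unreadable from compound 1 to compound 2 to go on, no shift beyond the usual scatter is expected in this assay in either direction, and compound 3 is expected to report a limit as well. The expected size is a number no higher from compound 2 to compound 3 (the limit leaves the size open) for this change. For compound 3 the estimate is 100000 nM with an expected range from 40000 nM to 200000 nM in case a number is reported at all.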

Compound 3, half-maximal inhibitory concentration: > 100000 nM
Compound 3 gave a limit, no number; the forecaster's own chance of this, stated with the estimate: 85%; the middle value sits exactly at the limit.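

In this assay compound 3 gives > 100000 nM, which is a limit and not a number. Going by these compounds alone, no step among compound 1, compound 2 and compound 3 can be read, and all three sit together: the limit of > 100000 nM in this assay, at which 3 of the 3 values shown sit. The compounds shown leave open whether cyclopropylamino, methylamino and dimethylamino differ at all in this assay.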